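The compounds below may be only part of what the source reports. "The series", "measured", "known", "first", "only" and "open" are said of these compounds alone.

Compound 1 `O=C(O)CCCn1c2ccc([N+](=O)[O-])cc2c(=O)n1Cc1ccccc1` and compound 2 `COCCn1c2ccc([N+](=O)[O-])cc2c(=O)n1Cc1ccccc1` share one core and differ only in a chain, and both were tested in an ADME assay on L929 cells (Mus musculus) for cytotoxicity, read by resazurin assay, with a stated time of 48 h; on this read-out lower numbers stand for higher toxicity in this test and higher numbers for lower toxicity in this test. Compound 1 gives > 256000 nM, which is a limit and not a number. Compound 2 gives > 256000 nM, which is also a limit. Compound 2 therefore has no exact place on the scale, and the evidence so far amounts to the limit of > 256000 nM in this assay, at which 2 of the 2 values shown sit.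

Compound 3 `Cc1ccc(S(=O)(=O)n2c3ccc([N+](=O)[O-])cc3c(=O)n2Cc2ccccc2)cc1` keeps the core but carries a new group on an aromatic nitrogen: (4-methylphenyl)sulfonyl in place of 2-methoxyethyl on an aromatic nitrogen. Among the measured compounds shown here, the only measured comparison is a step that the two limits leave unreadable from compound 1 to compound 2, and it also concerns the group on an aromatic nitrogen. That comparison gives no size to carry over, and neither compound 1 nor compound 2 has an aromatic ring in this group. Any expectation is therefore loose. Another limit remains quite possible in this assay, and if a number does appear, a move towards lower numbers is the only direction open. The estimated change is an at least 1.4-fold lower number from compound 2 to compound 3 (0.15 log units; that floor lies within the scatter). Compound 3 is expected near 180000 nM, with an estimated range from 50000 nM to 256000 nM.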

Compound 3, concentration lethal to 50% of the cells: > 256000 nM
Compound 3: no number, only a limit; the forecaster's own chance of this, stated with the estimate: 55%; at least 1.4-fold (0.15 log units) between middle value and limit.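

In this assay compound 3 gives > 256000 nM as a limit and not a number. Among the compounds shown here, compound 1, compound 2 and compound 3 all end at this limit, so no step among them can be read. Still open, going by these compounds, is whether any group on the aromatic nitrogen would bring a measurable number in this test. The evidence now stands as follows: the limit of > 256000 nM in this assay, at which 3 of the 3 values shown sit.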